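This account rests on a few compounds, and the source may have more. Where it says the series, first, only, none or still open, it means among the compounds named here.

Working notes on the series. Compound 3 is `CC(C(=O)N1CCC2(CC1)CC2)N1CCN(S(=O)(=O)c2ccc(C(C)(C)C)cc2)CC1`; compound 1 is `CC(C(=O)N1CCC(F)(F)CC1)N1CCN(S(=O)(=O)c2ccc(C(C)(C)C)cc2)CC1` and compound 2 is `CC1CCN(C(=O)C(C)N2CCN(S(=O)(=O)c3ccc(C(C)(C)C)cc3)CC2)CC1`, differing from it only in the group on the carbonyl carbon. In an ADME assay on HepG2 cells (Homo sapiens) for inhibition, with a stated time of 48 h (on this read-out higher numbers stand for an effect only at larger amounts of compound and lower numbers for an effect already at smaller amounts), compound 3 gives only a limit, > 40000 nM. Compound 1 likewise reaches only a limit in this assay, > 40000 nM. Compound 2 in this assay also stops at a limit, > 40000 nM. Compound 3 thus stands on no number of its own, and the two further values beside it are limits as well; the limit of > 40000 nM in this assay, at which 3 of the 3 values shown sit, covers everything measured so far. The steps a step that the two limits leave unreadable from compound 1 to compound 2, a step that the two limits leave unreadable from compound 1 to compound 3 and a step that the two limits leave unreadable from compound 2 to compound 3 are consequently all unreadable in size and direction.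

Compound 4 is `CC(C(=O)N1CCOCC1)N1CCN(S(=O)(=O)c2ccc(C(C)(C)C)cc2)CC1`. The change is a group of 6 heavy atoms (4 carbon, 1 nitrogen, 1 oxygen; one six-membered non-aromatic ring with 2 hetero atoms) in place of a group of 8 heavy atoms (7 carbon, 1 nitrogen; one three-membered non-aromatic ring of carbon only, one six-membered non-aromatic ring with 1 hetero atom), on a carbonyl carbon. Within the data shown here, no measured step gives a size to lean on, since each sits between two limits, so no step beyond the scatter can be read out of the series. The expectation for compound 4 is a further limit, with the step from compound 3 expected as a step that the limit leaves unreadable from compound 3 to compound 4. The estimated value for compound 4 in this assay is 60000 nM, expected to fall between 20000 nM and 200000 nM.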

Compound 4, half-maximal effective concentration: > 40000 nM
Compound 4: a limit, no number; the forecaster's own chance of this, stated with the estimate: 85%; the middle value lies beyond the limit too.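

In this assay compound 4 gives only a limit, > 40000 nM, and its steps from compound 1, compound 2 and compound 3 cannot be read: the limit of > 40000 nM in this assay, at which 4 of the 4 values shown sit.

The compounds shown leave open whether any group on the carbonyl carbon gives an actual number in this assay.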